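This account rests on a few compounds, and the source may have more. Where it says the series, first, only, none or still open, it means among the compounds named here.

Compound 1 `C#CCSc1nnc(C)n1N1C(=O)c2ccccc2C1=O` was examined in a functional assay on MKN-45 cells (Homo sapiens) for cytotoxicity, read by MTT assay, with a stated time of 48 h; a lower number here means a stronger inhibitor, a higher number a weaker inhibitor. In this assay compound 1 gives > 200000 nM, which is a limit of the assay rather than a number. Compound 2 `Cc1nnc(SCc2ccccc2Cl)n1N1C(=O)c2ccccc2C1=O` differs from compound 1 by 2-chlorophenyl in place of ethynyl on a saturated chain carbon bound to a sulfur. In this assay compound 2 gives > 200000 nM, again a limit. The step that the two limits leave unreadable from compound 1 to compound 2 therefore cannot be read. Compound 3 `C#CCSc1nnc(CCC)n1N1C(=O)c2ccccc2C1=O` differs from compound 1 by ethyl in place of hydrogen on a saturated chain carbon bound to an aromatic carbon. In this assay compound 3 gives > 200000 nM, also a limit. The step that the two limits leave unreadable from compound 1 to compound 3 is likewise unreadable. All three values rest at the limit of > 200000 nM in this assay, at which 3 of the 3 values shown sit.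

Compound 4 `CCCc1nnc(SCc2ccccc2Cl)n1N1C(=O)c2ccccc2C1=O` has not yet been measured. Compound 4 differs from compound 3 by 2-chlorophenyl in place of ethynyl on a saturated chain carbon bound to a sulfur, the same change as that from compound 1 to compound 2, made at the same place. The step that the limit leaves unreadable from compound 3 to compound 4 is expected to be essentially nil because the corresponding step that the two limits leave unreadable from compound 1 to compound 2 left both ends at the limit. Compound 4 is therefore expected to give about 300000 nM in this assay, most likely as a further limit, within a range from 150000 nM to 1000000 nM.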

Compound 4, half-maximal inhibitory concentration: > 200000 nM
Compound 4 gave a limit, no number; the forecaster's own chance of this, stated with the estimate: 85%; the middle value lies beyond the limit too.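

In this assay compound 4 gives > 200000 nM, a limit of the assay and not a number, so the steps to compound 4 from compound 3 and from compound 2 cannot be read. The compounds shown leave open how strong any of them is, and whether either change has any effect, with every value resting at the same limit: the limit of > 200000 nM in this assay, at which 4 of the 4 values shown sit.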